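A few compounds are considered here, and "the series" means these few. Any claim that something is new, unique, unknown or untested is made for them only; others in the source may bear on it.

Values in a functional assay on HL-60 cells (Homo sapiens) for cytotoxicity, read by CellTiter-Blue, with a stated time of 48 h; a lower number here means a stronger inhibitor, a higher number a weaker inhibitor:
- compound 1 `CCOC(=O)CC1C(C(=O)OCC)=C(N)Oc2ccc(-c3ccco3)cc21`: > 80000 nM, a limit of the assay
- compound 2 `CCOC(=O)CC1C(C(=O)OCC)=C(N)Oc2ccc(-c3cncnc3)cc21`: 37900 nM
- compound 3 `CCOC(=O)CC1C(C(=O)OCC)=C(N)Oc2ccc(-c3ccnc(OC)c3)cc21`: 10200 nM

Compound 3 has the lowest number of the three, and compound 2 is its nearest neighbour, with a 3.7-fold lower number from compound 2 to compound 3 (0.57 log units; beyond the scatter). Compound 1 stands at a limit, not a number: the limit of > 80000 nM in this assay, at which 1 of the 3 values shown sits.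

Compound 4 `CCOC(=O)CC1C(C(=O)OCC)=C(N)Oc2ccc(-c3cccc(NC)c3)cc21` carries 3-(methylamino)phenyl in place of 2-methoxypyridin-4-yl on an aromatic carbon. All three measured steps are swaps at this same place on the shared core. Two start from the limit and give only bounds: an at least 2.1-fold lower number from compound 1 to compound 2 (0.32 log units; beyond the scatter) and an at least 7.8-fold lower number from compound 1 to compound 3 (0.89 log units; beyond the scatter). Only a 3.7-fold lower number from compound 2 to compound 3 (0.57 log units; beyond the scatter) joins two real numbers, and it is modest. Going by the values given here, none of the measured compounds has a carbon-only ring at this place, so no direction can be expected with confidence in this assay. The expected result is a 1.1-fold lower number from compound 3 to compound 4 (0.05 log units; within the scatter), with a modest move either way still possible. For compound 4 the estimated value is 9000 nM, with an expected range of 2500 nM to 32000 nM.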

Compound 4, half-maximal inhibitory concentration: 7450 nM
Compound 4: the middle estimate sits 1.2-fold (0.08 log units) above what was measured, and the stated range covers the measured number.
By their numbers in this assay, from the lowest: compounds 4 and 3 (each within the scatter of the next); then compound 2. At a limit, above all of these: compound 1.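

Replacing 2-methoxypyridin-4-yl with 3-(methylamino)phenyl puts a carbon-only ring and a hydrogen-bond donor at this place, yet in this assay the two values do not separate: a 1.4-fold lower number from compound 3 to compound 4 (0.14 log units; within the scatter). Going by these compounds alone, a ring nitrogen in this group is therefore not required to reach this level, and the same change away from pyrimidin-5-yl gives a 5.1-fold lower number from compound 2 to compound 4 (0.71 log units; beyond the scatter), while the change away from furan-2-yl gives an at least 10-fold lower number from compound 1 to compound 4 (1.03 log units; beyond the scatter), the only step of this size and a bound rather than a measured difference. Compound 1 stands at a limit, not a number: the limit of > 80000 nM in this assay, at which 1 of the 4 values shown sits.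

Open, from the compounds shown here alone, is whether the methylamino group contributes at all, which an unsubstituted phenyl, a primary amine or a dimethylamino group at this place would test. Also open, going by these compounds, is how far a carboxylic acid in place of either ethyl ester would shift the values.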